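This account rests on a few compounds, and the source may have more. Where it says the series, first, only, none or still open, it means among the compounds named here.

Measured in a functional assay on HepG2 cells (Homo sapiens) for cytotoxicity, read by sulforhodamine B assay, with a stated time of 24 h; a lower number here means a stronger inhibitor, a higher number a weaker inhibitor:
compound 1 `O=C1Nc2ccc(S(=O)(=O)N3CCOCC3)cc2/C1=N/c1ccc(Br)cc1`: 11900 nM
compound 2 `O=C1Nc2ccc(S(=O)(=O)N3CCOCC3)cc2/C1=N/c1ccc(C(=O)O)cc1`: 23100 nM
compound 3 `O=C1Nc2ccc(S(=O)(=O)N3CCOCC3)cc2/C1=N/NS(=O)(=O)c1ccccc1`: 23900 nM

Compound 3 stands within the scatter of the other two, as a 2.0-fold higher number from compound 1 to compound 3 (0.30 log units; within the scatter) and a 1.0-fold higher number from compound 2 to compound 3 (0.01 log units; within the scatter) show. Compound 4 `O=C1Nc2ccc(S(=O)(=O)N3CCOCC3)cc2/C1=N/c1ccc(Cl)cc1` has no value yet. Its change from compound 3 is 4-chlorophenyl in place of (phenylsulfonyl)amino on a double-bonded nitrogen. Compound 1 carries 4-bromophenyl there, so its step to compound 3 is the closest guide. That step stays within the scatter, as does a 1.9-fold higher number from compound 1 to compound 2 (0.29 log units; within the scatter). No change beyond the scatter is therefore expected in this assay. The expected step is a 1.7-fold lower number from compound 3 to compound 4 (0.23 log units; within the scatter). For compound 4 the estimated value is 14000 nM, with an expected range from 7500 nM to 25000 nM.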

Compound 4, half-maximal inhibitory concentration: 11800 nM
Estimate against measurement, compound 4: 1.2-fold (0.07 log units) above; the measured number falls inside the stated range.
By their numbers in this assay, from the lowest: compounds 4, 1, 2 and 3 (each within the scatter of the next, the first and the last beyond it).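

In this assay, among these compounds, 4-chlorophenyl in place of (phenylsulfonyl)amino on the double-bonded nitrogen gives the first step in this set beyond the scatter, though a modest one (a 2.0-fold lower number from compound 3 to compound 4 (0.31 log units; beyond the scatter)). On the aromatic carbon, chloro in place of bromo (a 1.0-fold lower number from compound 1 to compound 4 (0.00 log units; within the scatter)) and chloro in place of carboxy (a 2.0-fold lower number from compound 2 to compound 4 (0.29 log units; within the scatter)) both stay within the scatter. Nothing given here bears on the cause of these results. Still open, from the compounds shown here alone, is how an amine or a methoxy group on that aromatic carbon would read in this assay.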